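From an octyl chain to a bromophenyl ring

The compounds below may be only part of what the source reports. "The series", "measured", "known", "first", "only" and "open" are said of these compounds alone.

Compound 1, `O=c1cc(Cn2cc(CCO)nn2)c2ccc(O)cc2o1`: > 100000 nM
Compound 2, `CC(C)(C)c1cn(Cc2cc(=O)oc3cc(O)ccc23)nn1`: > 100000 nM
Compound 3, `CCCCCCCCc1cn(Cc2cc(=O)oc3cc(O)ccc23)nn1`: 50900 nM

Three compounds share one core and differ only in the group on the triazole carbon; all were tested in a functional assay on SW-620 cells (Homo sapiens) for inhibition, read by MTT assay, with a stated time of 72 h; a lower number here means a stronger inhibitor, a higher number a weaker inhibitor. For compound 1 the value is a limit of the assay, not a number. The same holds for compound 2, whose value is also a limit. For the measured compounds named here, compound 3 therefore holds the only number, standing apart from the two limits because of the limit of > 100000 nM in this assay, at which 2 of the 3 values shown sit.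

The step from compound 1 to compound 3 was an at least 1.9-fold lower number from compound 1 to compound 3 (0.29 log units; that floor lies within the scatter), and that from compound 2 to compound 3 was an at least 1.9-fold lower number from compound 2 to compound 3 (0.29 log units; that floor lies within the scatter); the step from compound 1 to compound 2 is a step that the two limits leave unreadable from compound 1 to compound 2. So the one readable change at this position, to the octyl chain, moved the number only to a floor within the scatter.

Compound 4, `O=c1cc(Cn2cc(-c3ccc(Br)cc3)nn2)c2ccc(O)cc2o1`, is not yet measured. It differs from compound 3 by 4-bromophenyl in place of octyl on an aromatic carbon. Going by the values given here, no measured step exchanges a chain for an aromatic ring here, so the expectation rests on the octyl result alone. Compound 4 is expected to give 40000 nM, between 8000 nM and 150000 nM, a step of a 1.3-fold lower number from compound 3 to compound 4 (0.10 log units; within the scatter) that is expected to stay within the scatter.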

Compound 4, half-maximal inhibitory concentration: 97700 nM
Beside the measured number, compound 4's estimate is 2.4-fold (0.39 log units) below it; measured number inside the range.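

In this assay, for the compounds shown here, the exchange of the octyl chain for 4-bromophenyl on this aromatic carbon gives the first step at this position with a number at both ends: a 1.9-fold higher number from compound 3 to compound 4 (0.28 log units; within the scatter). At this position, then, this read-out does not tell an unbranched chain from a six-membered aromatic ring of carbon only, so the octyl result was not tied to a chain. The steps from the two other compounds are floors only, an at least 1.0-fold lower number from compound 2 to compound 4 (0.01 log units; that floor lies within the scatter) and an at least 1.0-fold lower number from compound 1 to compound 4 (0.01 log units; that floor lies within the scatter), and they do not separate compound 4 from those compounds because the reading of compound 4 sits so near the ceiling of the assay: the limit of > 100000 nM in this assay, at which 2 of the 4 values shown sit.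

The compounds shown leave open whether the bromine plays any part, since a plain phenyl ring, or an amine or a carboxylic acid in place of the bromine, would be needed to tell. They also leave open whether a chain longer than octyl at this position would bring the number down by more than the scatter.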